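The source may hold more compounds than are shown below. What is called first, only, known or untested is meant among the compounds shown, and "the series" means these compounds.

Measured compounds:
Compound 1, `CC(=O)OC(C)n1cnc2c(Cl)nc(N)nc21`, gives only a limit in a functional assay on FM3A cells (Homo sapiens) for inhibition, with FM3A (Mus musculus) as the target; on this read-out higher numbers stand for weaker inhibition and lower numbers for stronger inhibition: > 500000 nM.
Compound 2, `CC(=O)OC(C)n1cnc2c(Cl)nc(I)nc21`, gives 47000 nM in this assay.
Compound 3, `CC(=O)OCCOn1cnc2c(Cl)nc(I)nc21`, gives 34000 nM in this assay.

Compound 2 stands highest of the two numbers shown in this assay, but its nearest neighbour, compound 3, lies within the scatter of it, so no order between the two can be claimed. For compound 1 the read-out is a limit of this assay, not a number (the limit of > 500000 nM in this assay, at which 1 of the 3 values shown sits).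

Within the data shown here, the only measured step, an at least 10-fold lower number from compound 1 to compound 2 (1.02 log units; beyond the scatter), is a change on an aromatic carbon and does not touch the chain outside the shared core. Compound 4, `CC(O)n1cnc2c(Cl)nc(I)nc21`, differs from compound 2 by hydrogen in place of acetyl on an oxygen on a saturated carbon. Among the measured compounds shown here, no measured step bears directly on this change. Compound 2 and compound 3, which differ only in the chain outside the shared core, give values within the scatter of each other, which suggests that this chain is tolerant of alteration. The step from compound 2 to compound 4 is therefore expected to stay within the scatter: a 1.0-fold lower number from compound 2 to compound 4 (0.02 log units; within the scatter). Compound 4 is estimated at 45000 nM, with a range from 12000 nM to 170000 nM.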

Compound 4, half-maximal inhibitory concentration: 479000 nM
Estimate against measurement, compound 4: 11-fold (1.03 log units) below; the measured number lies above the stated range.
By their numbers in this assay, from the lowest: compounds 3 and 2 (each within the scatter of the next); then compound 4. At a limit, above all of these: compound 1.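

Among these compounds, the step of a 10-fold higher number from compound 2 to compound 4 (1.01 log units; beyond the scatter) is the first measured change in the chain outside the shared core that goes beyond the scatter in this assay. It shows that the acetyl on this oxygen cannot be replaced by hydrogen without a large loss, so the closeness of compound 2 and compound 3, which both keep the acetoxy group, does not extend to every alteration of the chain. Nothing at hand gives a reason for this step.

Going by these compounds, it remains open whether a methyl ether, a benzoyl ester or a longer ester such as propanoyl on this oxygen would read like the acetoxy group or like the hydroxy group. Also open, on these data alone, is how an amine in place of this oxygen would read, and whether the step would keep its size with amino rather than iodo on the aromatic carbon.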